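The source may hold more compounds than are shown below. What is called first, only, known or untested is meant among the compounds shown, and "the series" means these compounds.

Measured compounds in this series:

- compound 1 `CC(C)[C@@H]1CC[C@@H](C)C[C@@]12N(C)C(=O)[C@@H]1[C@H]3C(=O)N(C)C(=O)[C@H]3ON12`: in a functional assay, read by spectrophotometry, with a stated time of 2 h (on this read-out lower numbers stand for stronger inhibition and higher numbers for weaker inhibition), compound 1 gives 2160 ug/mL
- compound 2 `COc1ccc(N2C(=O)[C@H]3[C@H](ON4[C@@H]3C(=O)N(C)[C@@]43C[C@H](C)CC[C@H]3C(C)C)C2=O)cc1`: in this assay compound 2 gives 990 ug/mL

Going by the values given here, compound 2 holds the lowest of the two numbers so far; the only neighbour is compound 1, which stands higher by a 2.2-fold lower number from compound 1 to compound 2 (0.34 log units; beyond the scatter), a modest step.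

Compound 3 `Cc1cccc(N2C(=O)[C@H]3[C@H](ON4[C@@H]3C(=O)N(C)[C@@]43C[C@H](C)CC[C@H]3C(C)C)C2=O)c1` differs from compound 2 in one place: 3-methylphenyl in place of 4-methoxyphenyl on an amide-type nitrogen in a ring.

Among the compounds with values here, no measured step exchanges one aryl group for another on this nitrogen. Within the data shown here, the single step on record, a 2.2-fold lower number from compound 1 to compound 2 (0.34 log units; beyond the scatter), concerns an aryl group entering in place of methyl and bears only indirectly on the present change, in that an aryl group is retained in compound 3. With nothing measured that speaks to the methoxy-to-methyl swap, no step beyond the scatter is expected, estimated as a 1.0-fold higher number from compound 2 to compound 3 (0.00 log units; within the scatter).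

For compound 3 the expected value in this assay is 1000 ug/mL, with an estimated range from 500 ug/mL to 2000 ug/mL.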

Compound 3, half-maximal inhibitory concentration: 1930 ug/mL
Compound 3: the middle estimate sits 1.9-fold (0.29 log units) below what was measured; low and high end bracket the measured number.
By their numbers in this assay, from the lowest: compounds 2, 3 and 1 (each within the scatter of the next, the first and the last beyond it).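

In this assay, going by these compounds alone, 3-methylphenyl in place of 4-methoxyphenyl on this amide-type nitrogen gives the first aryl-for-aryl comparison at this position, with a 1.9-fold higher number from compound 2 to compound 3 (0.29 log units; within the scatter) as its step. 3-methylphenyl in place of methyl gives a 1.1-fold lower number from compound 1 to compound 3 (0.05 log units; within the scatter) as its step, so an aryl group on this nitrogen does not in itself yield a step beyond the scatter, and compound 3 goes against any such reading of the step to compound 2. No available data explain either step.

The exchange alters both the substituent and its ring position, so the shown compounds cannot separate these two changes; 4-methylphenyl and 3-methoxyphenyl on this nitrogen would do so. Also open, as far as these compounds go, is how this nitrogen tolerates an aryl group bearing an amine or a carboxylic acid, or a longer chain in place of the aryl group.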